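A Ring Swap on the Thiocarbonyl Side Chain

The compounds below may be only part of what the source reports. "The series", "measured", "known", "first", "only" and "open" are said of these compounds alone.

Three compounds sharing one core were tested in a functional assay on A-375 cells (Homo sapiens) for cytotoxicity, read by MTT assay, with a stated time of 72 h, tested at 10 uM; on this read-out higher numbers stand for more inhibition of growth at the one concentration tested and lower numbers for less inhibition of growth. Compound 1 `N/C(=N\NC(=S)N1CCOCC1)c1ccccn1` gives 18.3%. Compound 2 `Cc1ccnc(/C(N)=N/NC(=S)N2CCOCC2)c1` gives 86%, and compound 3 `N/C(=N\NC(=S)N1CCOCC1)c1ccc(F)cn1` gives 70.3%. Compound 2 stands highest of the three, ahead of compound 3 and far ahead of compound 1. Both measured steps alter the aromatic ring of compound 1: a number 67.7 percentage points higher from compound 1 to compound 2 (beyond the scatter) with methyl in place of hydrogen on an aromatic carbon, and a number 52 percentage points higher from compound 1 to compound 3 (beyond the scatter) with fluoro in place of hydrogen on an aromatic carbon.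

Compound 4 `Cc1ccnc(/C(N)=N/NC(=S)N2CCCCC2)c1` keeps the methyl-bearing aromatic ring of compound 2 and changes the other end of the molecule: piperidin-1-yl in place of morpholin-4-yl on a thiocarbonyl carbon. Going by the values given here, neither measured step touches this part of the structure; the ring attached to the thiocarbonyl carbon is the same in all three measured compounds, so no measured step bears directly on the change from compound 2 to compound 4. Without a direct guide, the expected step is one of no more than the usual scatter, a number 6 percentage points lower from compound 2 to compound 4 (within the scatter). Compound 4 is therefore estimated to give about 80% in this assay, with an expected range from 55% to 95%.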

Compound 4, percent growth inhibition at one concentration: 81.2%
Compound 4: middle estimate off by 1.2 percentage points, on the low side, within the range that was stated.
By their numbers in this assay, from the lowest: compound 1; then compound 3; then compounds 4 and 2 (each within the scatter of the next).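

In this assay, going by these compounds alone, piperidin-1-yl in place of morpholin-4-yl on a thiocarbonyl carbon comes with a number 4.8 percentage points lower from compound 2 to compound 4 (within the scatter) and gives the first reading of a change at this end of the molecule, since the earlier steps altered only the aromatic ring. The two groups have the same number of heavy atoms and differ in that morpholin-4-yl has a ring oxygen, counted as one hydrogen-bond acceptor, where piperidin-1-yl has a carbon, so removing that oxygen leaves compound 2 and compound 4 indistinguishable on this read-out. This holds for one pair carrying the methyl-bearing aromatic ring, and no measurement shown here offers an explanation for the result.

Still open, on these data alone, is whether a group of a different kind on the thiocarbonyl carbon, such as an open-chain dimethylamino group or a piperazine ring with a free amine, would stay level with these two compounds or fall away. As far as these compounds go, it is also open whether the same ring exchange would behave alike on the unsubstituted aromatic ring of compound 1 at 18.3% in this assay as it does on the methyl-bearing ring.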